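The source may report more compounds than this note shows. Statements on the series, on what has been measured and on what is new or still open speak of the compounds shown alone.

Compound 1 `O=C(O)Cc1sc(C(c2ccc(F)cc2)c2ccc(F)cc2)nc1-c1ccc(Cl)cc1` gives 180 nM in an in vitro functional assay on HEK285-7 cells for antagonist activity at prostaglandin D2 receptor 2 (Homo sapiens), read by BRET and beta-arrestin recruitment; a higher number here means a weaker inhibitor, a lower number a stronger inhibitor. Within the data shown here, compound 2 `N#Cc1ccc(-c2nc(C(c3ccc(F)cc3)c3ccc(F)cc3)sc2CC(=O)O)cc1` gives 1500 nM in this assay, the higher of the two numbers recorded, and the only measured step is an 8.3-fold higher number from compound 1 to compound 2 (0.92 log units; beyond the scatter). Compound 3 `CS(=O)(=O)Nc1cccc(-c2nc(C(c3ccc(F)cc3)c3ccc(F)cc3)sc2CC(=O)O)c1` differs from compound 2 in one place: 3-(methanesulfonamido)phenyl in place of 4-cyanophenyl on an aromatic carbon. Among the measured compounds shown here, no measured step involves a methanesulfonamido group, so that one step is only a loose guide, showing that a change on this phenyl ring can move the number beyond the scatter. For compound 3 the expected step is a 2.5-fold lower number from compound 2 to compound 3 (0.40 log units; beyond the scatter). Compound 3 is therefore estimated at 600 nM in this assay, within a range from 150 nM to 2500 nM.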

Compound 3, half-maximal inhibitory concentration: 370 nM
Compound 3: middle estimate off by 1.6-fold (0.21 log units), on the high side; the range from low to high includes it.
By their numbers in this assay, from the lowest: compound 1; then compound 3; then compound 2.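

Putting 3-(methanesulfonamido)phenyl in place of 4-cyanophenyl gives a 4.1-fold lower number from compound 2 to compound 3 (0.61 log units; beyond the scatter) and shows that this position can take a group with more heavy atoms and a hydrogen-bond donor without a further loss. The same group in place of 4-chlorophenyl gives a 2.1-fold higher number from compound 1 to compound 3 (0.31 log units; beyond the scatter) and leaves compound 1 the strongest inhibitor of the three. Nothing available explains these differences.

As far as these compounds go, whether the methanesulfonamido group itself or its place on the phenyl ring matters stays open. From the compounds shown here alone, how a phenyl ring carrying an amine or a carboxylic acid would compare also stays open.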